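Working notes on piperidin-1-yl sulfonyl analogues

The compounds below may be only part of what the source reports. "The series", "measured", "known", "first", "only" and "open" are said of these compounds alone.

Compound 1 `CC1CCN(S(=O)(=O)c2ccc(NC(=O)c3ccc([N+](=O)[O-])o3)cc2)CC1` carries a single methyl on a saturated ring carbon of the piperidine ring that sits on the sulfonyl sulfur. In an ADME assay on IMR-90 cells (Homo sapiens) for cytotoxicity, read by CellTiter-Blue, with a stated time of 46 h (on this read-out higher numbers stand for an effect only at larger amounts of compound and lower numbers for an effect already at smaller amounts), compound 1 gives only a limit, > 25000 nM. Compound 2 `CC1(C)CCN(S(=O)(=O)c2ccc(NC(=O)c3ccc([N+](=O)[O-])o3)cc2)CC1` has a second methyl in place of hydrogen on that same ring carbon. In this assay compound 2 also gives only a limit, > 25000 nM. Going by the values given here, the step that the two limits leave unreadable from compound 1 to compound 2 therefore cannot be read in either direction, and compound 2 stands at the limit alongside the only other value shown, as summarised by the limit of > 25000 nM in this assay, at which 2 of the 2 values shown sit.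

Compound 3 `CC(C)(C)C1CCN(S(=O)(=O)c2ccc(NC(=O)c3ccc([N+](=O)[O-])o3)cc2)CC1` is the next variation on the sulfonyl sulfur: 4-(tert-butyl)piperidin-1-yl in place of 4,4-dimethylpiperidin-1-yl on a sulfonyl sulfur. Among the compounds with values here, the one measured step that bears on it is the unreadable a step that the two limits leave unreadable from compound 1 to compound 2, so no size or direction beyond the scatter can be drawn from the series. On that basis compound 3 is expected to sit at or past the limit as well, with an estimated value of 40000 nM in this assay, within a range from 15000 nM to 120000 nM. The step this estimate implies is a step that the limit leaves unreadable from compound 2 to compound 3, expected to stay within the scatter.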

Compound 3, half-maximal effective concentration: > 25000 nM
Compound 3: only a limit was reported; the forecaster's own chance of this, stated with the estimate: 80%; the middle value lies beyond the limit too.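

In this assay compound 3 gives only a limit, > 25000 nM. No new step can be read among compound 1, compound 2 and compound 3, which share one limit: the limit of > 25000 nM in this assay, at which 3 of the 3 values shown sit.

The compounds shown leave open where any of the three would reach its half-maximal effect, and whether the groups on the sulfonyl sulfur differ in this assay at all.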